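This account rests on a few compounds, and the source may have more. Where it says the series, first, only, none or still open, it means among the compounds named here.

- Compound 1 `O=C(c1ccccn1)N1CCC(NS(=O)(=O)c2cc(S(=O)(=O)c3ccccc3)ccc2C(F)(F)F)CC1`: 100000 nM
- Compound 2 `O=C(c1ccc(Cl)nc1)N1CCC(NS(=O)(=O)c2cc(S(=O)(=O)c3ccccc3)ccc2C(F)(F)F)CC1`: 25000 nM
- Compound 3 `O=S(=O)(NC1CCN(S(=O)(=O)c2ccccc2)CC1)c1cc(S(=O)(=O)c2ccccc2)ccc1C(F)(F)F`: not yet measured

In a physicochemical assay for solubility (on this read-out higher numbers stand for higher solubility and lower numbers for lower solubility), compound 2 gives 25000 nM, the lower of the two numbers. Compound 3 differs from it as follows: phenylsulfonyl in place of (6-chloropyridin-3-yl)carbonyl on an amine nitrogen in a ring. In short, phenylsulfonyl replaces (6-chloropyridin-3-yl)carbonyl on an amine nitrogen in a ring. Among the measured compounds shown here, only one measured step bears on this, a 4.0-fold lower number from compound 1 to compound 2 (0.60 log units; beyond the scatter). That step kept the carbonyl, so it is a loose guide. A further modest drop in this assay is expected, estimated as a 2.5-fold lower number from compound 2 to compound 3 (0.40 log units; beyond the scatter). For compound 3 the estimated value is 10000 nM, with an expected range of 2500 nM to 40000 nM.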

Compound 3, solubility: 25000 nM
Compound 3: the middle estimate sits 2.5-fold (0.40 log units) below what was measured, and the stated range covers the measured number.
By their numbers in this assay, from the lowest: compounds 2 and 3 (each within the scatter of the next); then compound 1.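

On the amine nitrogen in the ring, phenylsulfonyl in place of (6-chloropyridin-3-yl)carbonyl gives no change at the digits printed from compound 2 to compound 3 (within the scatter) in this assay, so here a sulfonyl link and a carbonyl link read alike. Set against (pyridin-2-yl)carbonyl, the same phenylsulfonyl gives a 4.0-fold lower number from compound 1 to compound 3 (0.60 log units; beyond the scatter), which leaves compound 1 alone at the top of the three. No measurement here explains either step. Still open, going by these compounds, is whether the pyridin-2-yl ring or its carbonyl link sets compound 1 apart, which a pyridin-2-ylsulfonyl group on this nitrogen could separate. On these data alone, how an amine or a carboxylic acid on that group would read also remains open.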